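Working notes: replacing the 2-methoxyphenyl of compound 2

The source may report more compounds than this note shows. Statements on the series, on what has been measured and on what is new or still open speak of the compounds shown alone.

In a functional assay on DU-145 cells (Homo sapiens) for inhibition, read by trypan blue exclusion, with a stated time of 96 h (on this read-out lower numbers stand for stronger inhibition of growth and higher numbers for weaker inhibition of growth), compound 2 `COc1ccccc1/C=C(/SCc1ccc(Cl)cc1)C(=O)c1ccc(Cl)cc1` gives 1000 nM, the lowest of three numbers, against compound 1 `COc1ccccc1/C=C(/SCc1ccc(Cl)c(Cl)c1)C(=O)c1ccc(Cl)cc1` at 10000 nM and compound 3 `COc1ccccc1/C=C(/SCc1ccc(C)cc1)C(=O)c1ccc(Cl)cc1` at 10000 nM. Compound 4 `Cc1ccc(C)c(/C=C(/SCc2ccc(Cl)cc2)C(=O)c2ccc(Cl)cc2)c1` carries 2,5-dimethylphenyl in place of 2-methoxyphenyl on a double-bonded chain carbon bound to a double-bonded chain carbon. Within the data shown here, the measured steps, a 10-fold lower number from compound 1 to compound 2 (1.00 log units; beyond the scatter) and a 10-fold higher number from compound 2 to compound 3 (1.00 log units; beyond the scatter), both lie elsewhere in the molecule, so no measured step tests this change directly. They bear on it only indirectly: a 10-fold higher number from compound 2 to compound 3 (1.00 log units; beyond the scatter) shows a single change raising the number, so a modest rise is expected. The expected change is a 3.0-fold higher number from compound 2 to compound 4 (0.48 log units; beyond the scatter), toward weaker inhibition of growth. For compound 4 the estimated value is 3000 nM, with an expected range of 600 nM to 10000 nM.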

Compound 4, concentration for 50% growth inhibition: 10000 nM
For compound 4 the middle estimate is 3.3-fold (0.52 log units) below the measured one; low and high end bracket the measured number.
By their numbers in this assay, from the lowest: compound 2; then compounds 1, 3 and 4 (each within the scatter of the next).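

Among these compounds, this is the first measured change at the double-bonded chain carbon, and a 10-fold higher number from compound 2 to compound 4 (1.00 log units; beyond the scatter) in this assay shows that this position is not indifferent to the aryl group it carries. Here 2,5-dimethylphenyl, with no hydrogen-bond acceptor, replaces 2-methoxyphenyl, which has one. Nothing available explains the rise.

A single replacement cannot separate loss of the methoxy group from gain of the two methyl groups. A plain phenyl or an aminophenyl at this place would test whether any replacement retains the number of compound 2.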